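The compounds below may be only part of what the source reports. "The series", "measured", "known", "first", "only" and "open" are said of these compounds alone.

Of the compounds shown here, three built on one shared core have been measured in a physicochemical assay for lipophilicity, measured as octanol-water partition; a higher number here means a more lipophilic compound, a lower number a more polar compound. Compound 1 `O=C(COc1cccc2ccccc12)N/N=C/c1cccc(O)c1` gives 3.73, compound 2 `O=C(COc1cccc2ccccc12)N/N=C/c1cccc(Br)c1` gives 4.81, and compound 3 `COc1ccc(/C=N/NC(=O)COc2cccc3ccccc23)cc1` gives 3.77. Compound 3 therefore sits second highest of the three, with compound 1 so close that the two cannot be told apart within the scatter, while compound 2 stands well above it.

The step from compound 3 to compound 4 `O=C(COc1cccc2ccccc12)N/N=C/c1cccc(Cl)c1` exchanges one aromatic group for another: 3-chlorophenyl in place of 4-methoxyphenyl on a carbon with a double bond to nitrogen. Going by the values given here, two measured steps bear on this change. a number 1.04 log units lower from compound 2 to compound 3 (beyond the scatter), so the reverse direction, replacing a 4-methoxyphenyl with a 3-bromophenyl, raised the number by that same large amount. Likewise a number 1.08 log units higher from compound 1 to compound 2 (beyond the scatter), so the bromo compound sits high whether compared against a hydroxy or a methoxy partner. Compound 4 carries a 3-chlorophenyl where compound 2 carries a 3-bromophenyl, so a large upward step in this assay is expected, bringing compound 4 close to compound 2, which gives 4.81.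

Compound 4 is estimated to give 4.6 in this assay, with an expected range from 4.3 to 4.9. The step this estimate implies, a number 0.83 log units higher from compound 3 to compound 4 (beyond the scatter), is expected to be large and well beyond the scatter.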

Compound 4, partition coefficient: 4.54
Compound 4: the middle estimate sits 0.06 log units above what was measured, within the range that was stated.
By their numbers in this assay, from the lowest: compounds 1 and 3 (each within the scatter of the next); then compounds 4 and 2 (each within the scatter of the next).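

In this assay, compound 4 shows that the high number of compound 2 does not depend on bromo alone: chloro in its place leaves the two compounds within the scatter of each other (a number 0.27 log units lower from compound 2 to compound 4 (within the scatter)). Chloro also stands clear of both lower partners, whether it replaces hydroxy on the aromatic carbon (a number 0.81 log units higher from compound 1 to compound 4 (beyond the scatter)) or 3-chlorophenyl replaces 4-methoxyphenyl on the carbon with a double bond to nitrogen (a number 0.77 log units higher from compound 3 to compound 4 (beyond the scatter)), so the split seen with bromo is repeated with a second group. No measurement is available here to explain why these groups fall as they do.

With only hydroxy, bromo, chloro and methoxy on this ring, the compounds shown leave open where a group such as an amine, a carboxylic acid or a simple methyl would fall on this scale. The step involving compound 3 also changes the group and its place on the ring together, and a 3-methoxyphenyl or 4-chlorophenyl partner would be needed to pull those two changes apart.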